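Chloro to methylamino on the longer-chain compound

The source may report more compounds than this note shows. Statements on the series, on what has been measured and on what is new or still open speak of the compounds shown alone.

Measured in a functional assay on HCT-116 cells (Homo sapiens) for antiproliferative activity, read by MTT assay, with a stated time of 48 h; on this read-out higher numbers stand for weaker inhibition and lower numbers for stronger inhibition:
- Compound 1 `CCCCCCCC(CCO)n1cnc2c(NC)ncnc21` gives 12500 nM
- Compound 2 `CCCCCCCCCC(CCO)n1cnc2c(Cl)ncnc21` gives 890 nM

Compound 2 holds the lower of the two numbers in this assay, beyond the scatter from compound 1. Compound 3 `CCCCCCCCCC(CCO)n1cnc2c(NC)ncnc21` keeps the chain of compound 2, with methylamino in place of chloro on an aromatic carbon. Within the data shown here, no measured step isolates this change. Compound 1 carries methylamino on a shorter chain and gives 12500 nM, so weaker inhibition, beyond the scatter, is expected. The expected change is a 4.5-fold higher number from compound 2 to compound 3 (0.65 log units; beyond the scatter). For compound 3 the estimated value is 4000 nM, with an expected range of 1300 nM to 13000 nM.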

Compound 3, half-maximal inhibitory concentration: 5410 nM
For compound 3 the middle estimate is 1.4-fold (0.13 log units) below the measured one; the measured number falls inside the stated range.
By their numbers in this assay, from the lowest: compound 2; then compound 3; then compound 1.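

In this assay, methylamino in place of chloro on an aromatic carbon gives a 6.1-fold higher number from compound 2 to compound 3 (0.78 log units; beyond the scatter) on the longer chain, so this position now has a step of its own, and it favours chloro. With methylamino held fixed, ethyl in place of hydrogen on a saturated chain carbon gives a 2.3-fold lower number from compound 1 to compound 3 (0.36 log units; beyond the scatter) in the same assay, so the chain also moves the number.

No measurement at hand accounts for either step. As far as these compounds go, whether an unsubstituted amine or methoxy at this position, or a longer chain, would give a lower number than chloro remains open.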